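The source may hold more compounds than are shown below. What is called first, only, known or untested is meant among the compounds shown, and "the series" means these compounds.

Compound 1, whose structure is `O=C1O[C@H]([C@@H](O)Cn2cc(-c3cccc(O)c3)nn2)C(OCc2ccccc2)=C1OCc1ccccc1`, is the only one of the three measured compounds to give a number in a functional assay on CFPAC-1 cells (Homo sapiens) for antiproliferative activity, read by MTT assay, with a stated time of 72 h (on this read-out lower numbers stand for stronger inhibition and higher numbers for weaker inhibition), and that number is 54100 nM. Compound 2, with the structure `COc1ccc(-c2cn(C/C=C3\OC(=O)C(OCc4ccccc4)=C3OCc3ccccc3)nn2)cc1`, gives only a limit of the assay in this assay, reported as > 100000 nM. Compound 3, with the structure `COc1ccccc1-c1cn(C/C=C2\OC(=O)C(OCc3ccccc3)=C2OCc2ccccc2)nn1`, likewise gives only a limit in this assay, reported as > 100000 nM. For the measured compounds named here, the one step between measured compounds, a step that the two limits leave unreadable from compound 2 to compound 3, cannot be read, since both ends sit at the limit (the limit of > 100000 nM in this assay, at which 2 of the 3 values shown sit).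

The unmeasured compound 4 has the structure `COc1ccc(-c2cn(C[C@H](O)[C@H]3OC(=O)C(OCc4ccccc4)=C3OCc3ccccc3)nn2)cc1`. It keeps the core of compound 1 and differs from it in one place: 4-methoxyphenyl in place of 3-hydroxyphenyl on an aromatic carbon. Going by the values given here, no measured step bears directly on this change, because the two compounds that carry the 4-methoxyphenyl group, compound 2 and compound 3, both sit at the limit (the limit of > 100000 nM in this assay, at which 2 of the 3 values shown sit) and share a different core. What compound 2 and compound 3 show is that the 4-methoxyphenyl group has not so far gone with a readable number. The estimate for compound 4 is therefore a value near the limit, expressed as a step of a 1.8-fold higher number from compound 1 to compound 4 (0.27 log units; within the scatter) in the weaker direction, and compound 4 is expected to give about 100000 nM, with a range from 40000 nM to 250000 nM.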

Compound 4, half-maximal inhibitory concentration: 26000 nM
Compound 4: the middle estimate sits 3.8-fold (0.59 log units) above what was measured; measured number below the stated range.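

The change from 3-hydroxyphenyl to 4-methoxyphenyl, on an aromatic carbon of a five-membered aromatic ring with 3 nitrogen, gives in this assay a 2.1-fold lower number from compound 1 to compound 4 (0.32 log units; beyond the scatter), a modest step that lies beyond the usual scatter. On the core of compound 1, the hydrogen-bond donor of the 3-hydroxyphenyl group is therefore not required for a readable number at this position, and the 4-methoxyphenyl group is not tied to the limit of the assay. Until now that group had appeared only on a different core, in compound 2, and the 2-methoxyphenyl group only in compound 3, where neither compound gave a number and the step between them cannot be read: the limit of > 100000 nM in this assay, at which 2 of the 4 values shown sit.

The single step changes the hydroxyl to a methoxy group and changes the name of the ring position together, so the compounds shown do not separate the two, and 4-hydroxyphenyl or 3-methoxyphenyl on the same core would be needed to do so. As far as these compounds go, it also remains open how this position responds to a phenyl ring bearing an amine or a carboxylic acid, or to a longer chain in place of the phenyl ring.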